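Aryl hydrazone urea series: trimethoxy variant of compound 2

A few compounds are considered here, and "the series" means these few. Any claim that something is new, unique, unknown or untested is made for them only; others in the source may bear on it.

Compound 1 `CN(C)CCn1cnnc1-c1cc(Oc2ccc(NC(=O)N/N=C/c3cc(C(C)(C)C)cc(C(C)(C)C)c3O)cc2F)ccn1`, compound 2 `COc1ccc(/C=N/NC(=O)Nc2ccc(Oc3ccnc(-c4nncn4CCN(C)C)c3)c(F)c2)c(OC)c1` and compound 3 `Cn1ncnc1-c1cc(Oc2ccc(NC(=O)N/N=C/c3ccccc3)cc2F)ccn1` share a hydrazone urea attached to a fluorinated diaryl ether. In a functional assay on U-87MG ATCC cells (Homo sapiens) for cytotoxicity, read by MTT assay, with a stated time of 72 h (a higher number here means a weaker inhibitor, a lower number a stronger inhibitor), compound 1 gives 520 nM. In this assay compound 2 gives 12600 nM, the higher of the two numbers, and its gap to compound 1 lies beyond the scatter. For compound 3, this assay reports only a limit, > 100000 nM, which is the limit of > 100000 nM in this assay, at which 1 of the 3 values shown sits, and is not a number.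

Compound 4 `COc1cc(/C=N/NC(=O)Nc2ccc(Oc3ccnc(-c4nncn4CCN(C)C)c3)c(F)c2)cc(OC)c1OC` has not been measured. It differs from compound 2 by 3,4,5-trimethoxyphenyl in place of 2,4-dimethoxyphenyl on a carbon with a double bond to nitrogen. Going by the values given here, no measured pair shows the effect of changing the methoxy pattern on this ring, so no direction is firmly supported; the step from compound 2 to compound 4 in this assay is expected to be a 1.2-fold higher number from compound 2 to compound 4 (0.08 log units; within the scatter), small and within the scatter, with the possibility of a limit not excluded. For compound 4 in this assay the expected value is 15000 nM, with a range from 4000 nM to 60000 nM.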

Compound 4, half-maximal inhibitory concentration: 22500 nM
Estimate against measurement, compound 4: 1.5-fold (0.18 log units) below; low and high end bracket the measured number.
By their numbers in this assay, from the lowest: compound 1; then compounds 2 and 4 (each within the scatter of the next). At a limit, above all of these: compound 3.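

In this assay, going by these compounds alone, the first pair that differs in one place reads as a 1.8-fold higher number from compound 2 to compound 4 (0.25 log units; within the scatter). On the carbon with a double bond to nitrogen, 3,4,5-trimethoxyphenyl and 2,4-dimethoxyphenyl therefore cannot be told apart in this cell read-out, so the added methoxy group and the altered methoxy pattern together leave no resolved change at this position. No measurement shown here bears on why this exchange gives so small a step.

The pair covers only two methoxy patterns, so it cannot separate the effect of the number of methoxy groups from that of their placement. Also open, going by these compounds, is what a ring carrying a single methoxy group, an amine or a carboxylic acid would give at this position in this assay.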